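Cyano in Place of Hydrogen on the Sulfonyl Ring

The source may hold more compounds than are shown below. What is called first, only, known or untested is meant among the compounds shown, and "the series" means these compounds.

The set comprises three measured sulfonyl hydrazides and one yet to be tested. Compound 1 `CC(=O)Nc1ccc(S(=O)(=O)NNc2cccc(Br)c2)cc1` gives 7560 nM in an assay on HeLa cells for inhibition of Indoleamine 2,3-dioxygenase 1 (Homo sapiens), read by spectrophotometry, with a stated time of 24 h; a lower number here means that less compound is needed, a higher number that more compound is needed for the effect. Compound 2 `CC(=O)Nc1ccc(S(=O)(=O)NNc2ccc(Cl)c(Cl)c2)cc1` gives 350 nM in this assay. Compound 3 `O=S(=O)(NNc1ccc(Br)cc1)c1ccccc1` gives 128 nM in this assay, the lowest of the three numbers; compound 2 lies at a higher number beyond the scatter, and compound 1 is further away still. The pair from compound 3 to compound 4 `N#Cc1ccc(S(=O)(=O)NNc2ccc(Br)cc2)cc1` is not itself measured, but the structural change is counted: cyano in place of hydrogen on an aromatic carbon of a six-membered aromatic ring of carbon only, para to a large group. Compounds 1 and 2 carry a different group at that place, yet they also differ on the other ring, so no step can be read off. An expected step from compound 3 to compound 4 is therefore small, a 1.6-fold higher number from compound 3 to compound 4 (0.19 log units; within the scatter), none clearly beyond the scatter in either direction. Compound 4 is estimated at 200 nM, with a range from 50 nM to 800 nM.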

Compound 4, half-maximal effective concentration: 134 nM
For compound 4 the middle estimate is 1.5-fold (0.17 log units) above the measured one; the range from low to high includes it.
By their numbers in this assay, from the lowest: compounds 3 and 4 (each within the scatter of the next); then compound 2; then compound 1.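

In this assay, cyano in place of hydrogen on an aromatic carbon gives a step (a 1.0-fold higher number from compound 3 to compound 4 (0.02 log units; within the scatter)) that lies within the scatter, so the two compounds cannot be told apart. Among these compounds, this is the first pair in the set that differs in one place only, and it shows that at this place, para to a large group, a group of 2 heavy atoms with a triple bond and a hydrogen-bond acceptor can enter while the number stays within the scatter. No measurement bears on why this is so.

On these data alone, whether an amine, a carboxylic acid or a longer chain at the same place would also stay within the scatter remains open. So does whether cyano would give a similar step with a different group on the other ring.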